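Swapping the Aryl Group on the Shared Core

The source may report more compounds than this note shows. Statements on the series, on what has been measured and on what is new or still open speak of the compounds shown alone.

In a functional assay on NCI-H226 cells (Homo sapiens) for inhibition, read by MTT assay, with a stated time of 48 h, tested at 10 uM (on this read-out lower numbers stand for less inhibition and higher numbers for more inhibition at the one concentration tested (going by the name of the read-out)), compound 1 `COc1cc(NC(=O)Nc2cc(Nc3cc(Br)ccc3OC)ncn2)cc(OC)c1` gives 42.7% and compound 2 `COc1cc(Br)ccc1Nc1cc(NC(=O)Nc2c(Cl)cccc2Cl)ncn1` gives 43%. Compound 3 `COc1cc(NC(=O)Nc2cc(Nc3cc(C)cc(F)c3)ncn2)cc(OC)c1` gives 35.3% in this assay, the lowest of the three numbers, though its gaps to compound 1 and compound 2 both fall within the scatter. Compound 4 `CCc1ccc(Nc2cc(NC(=O)Nc3cc(OC)cc(OC)c3)ncn2)cc1` differs from compound 3 by 4-ethylphenyl in place of 3-fluoro-5-methylphenyl on a nitrogen on an aromatic ring. Among the measured compounds shown here, the one measured step of this kind, exchanging one aryl group for another on the same nitrogen, was a number 7.4 percentage points lower from compound 1 to compound 3 (within the scatter), which stayed within the scatter. A step of similar size is therefore expected here, so compound 4 is estimated to show a number 2.7 percentage points higher from compound 3 to compound 4 (within the scatter) in this assay. Compound 4 is expected to give 38%, between 25% and 52%.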

Compound 4, a percentage reported as inhibition, at one concentration (the size of the read-out at that concentration, not a potency): 50.1%
Estimate against measurement, compound 4: 12.1 percentage points below, and the stated range covers the measured number.
By their numbers in this assay, from the lowest: compounds 3, 1, 2 and 4 (each within the scatter of the next, the first and the last beyond it).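

In this assay, among the compounds shown here, the aryl group on this nitrogen can change the read-out: a number 14.8 percentage points higher from compound 3 to compound 4 (beyond the scatter) is the first step here to pass beyond the scatter, although 4-ethylphenyl and 3-fluoro-5-methylphenyl have the same heavy-atom count. The other step, a number 7.4 percentage points higher from compound 1 to compound 4 (within the scatter), does not separate 4-ethylphenyl from 5-bromo-2-methoxyphenyl. No evidence here accounts for the larger step. Still open, from the compounds shown here alone, is whether the ethyl group's place on the ring matters, and how a non-aryl group, such as a propyl chain or a piperidine, would read out on this nitrogen.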